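Bromo-fluorophenyl variation on the shared core

A few compounds are considered here, and "the series" means these few. Any claim that something is new, unique, unknown or untested is made for them only; others in the source may bear on it.

Working notes on a small series around one shared core. Compound 1 `C=CCn1c(=O)/c(=C\c2cccc(F)c2)[nH]c(=O)/c1=C\c1ccccc1OC` carries a 3-fluorophenyl on a double-bonded chain carbon bound to an aromatic carbon. Among the compounds with values here, in a functional assay on MOLT-4 cells (Homo sapiens) for cytotoxicity, read by CCK-8 assay, with a stated time of 72 h (a higher number here means a weaker inhibitor, a lower number a stronger inhibitor), compound 1 gives 6500 nM, the lowest of the two numbers so far. Compound 2 `C=CCn1c(=O)/c(=C\c2cc(Br)ccc2F)[nH]c(=O)/c1=C\c1ccccc1OC` replaces that group with a 5-bromo-2-fluorophenyl; in this assay compound 2 gives 12900 nM. Within the data shown here, the step of a 2.0-fold higher number from compound 1 to compound 2 (0.30 log units; within the scatter) is the only measured change at this place, and it does not exceed the scatter.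

Compound 3 `C=CCn1c(=O)/c(=C\c2ccc(F)c(Br)c2)[nH]c(=O)/c1=C\c1ccccc1OC` is not yet measured. Its change from compound 1 is 3-bromo-4-fluorophenyl in place of 3-fluorophenyl on a double-bonded chain carbon bound to an aromatic carbon. This is the same kind of change as from compound 1 to compound 2, a bromo-fluorophenyl replacing the fluorophenyl at the same place, differing only in which bromo-fluorophenyl enters. That single measured step was within the scatter, so nothing beyond the scatter is expected in this assay for compound 3, perhaps leaning toward a slightly higher number as in the step to compound 2. Compound 3 is therefore expected to show a step of a 1.4-fold higher number from compound 1 to compound 3 (0.14 log units; within the scatter) in this assay. The estimate for compound 3 in this assay is 9000 nM, with a range from 4000 nM to 20000 nM.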

Compound 3, half-maximal inhibitory concentration: "not active" (no number reported)
Compound 3: no number reported; there is nothing to compare the estimate with.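

Within the data shown here, compound 3 is reported as not active in this assay, with no number, and so no step from compound 1 to compound 3 can be read. The compounds shown leave open how the 3-bromo-4-fluorophenyl compares numerically with the 3-fluorophenyl on the shared core. Nothing available bears on this result.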